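This account rests on a few compounds, and the source may have more. Where it says the series, first, only, none or still open, it means among the compounds named here.

Within the data shown here, compound 2, `CCN1CCN(c2cc(C)c3cc(NC(=O)c4ccc(F)c(F)c4)ccc3n2)CC1`, is the stronger of the two compounds measured so far in a functional assay on SK-BR-3 cells (Homo sapiens) for antiproliferative activity, read by MTT assay, with a stated time of 72 h; a lower number here means a stronger inhibitor, a higher number a weaker inhibitor: compound 2 gives 1980 nM, while compound 1, `CCN1CCN(c2cc(C)c3cc(NC(=O)c4ccccc4)ccc3n2)CC1`, gives 18400 nM. Among the measured compounds shown here, the only measured step is the one that separates them, a 9.3-fold lower number from compound 1 to compound 2 (0.97 log units; beyond the scatter), a gain that stands beyond the scatter. Compound 3, `CCN1CCN(c2cc(C)c3cc(NC(=O)c4cccc(Br)c4)ccc3n2)CC1`, is the next compound to be tested, and the change it brings is 3-bromophenyl in place of 3,4-difluorophenyl on a carbonyl carbon. For the measured compounds named here, no measured pair shows a bromine on this ring, so the one step that bears on compound 3 is the gain from compound 1 to compound 2, which tells only that a ring with two fluorines outperforms a bare ring. Compound 3 keeps a substituted ring, but a different one, and compound 3 is therefore expected to land between the two measured values, with a step of a 1.8-fold higher number from compound 2 to compound 3 (0.25 log units; within the scatter) toward a weaker result. The estimate for compound 3 in this assay is 3500 nM, within a range from 1200 nM to 10000 nM.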

Compound 3, half-maximal inhibitory concentration: 13300 nM
Beside the measured number, compound 3's estimate is 3.8-fold (0.58 log units) below it, and the stated range ends below it.
By their numbers in this assay, from the lowest: compound 2; then compounds 3 and 1 (each within the scatter of the next).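

In this assay, 3-bromophenyl in place of 3,4-difluorophenyl on the carbonyl carbon gives a 6.7-fold higher number from compound 2 to compound 3 (0.83 log units; beyond the scatter), which takes back most of the gain that compound 2 had shown. Against the bare phenyl ring, bromo in place of hydrogen on an aromatic carbon gives a 1.4-fold lower number from compound 1 to compound 3 (0.14 log units; within the scatter), so in this series a halogen on this ring does not by itself bring the gain seen with compound 2. Nothing at hand explains the difference between the two halogenated rings.

Compound 2 and compound 3 differ in the kind of halogen, in how many the ring carries and in where they sit, and the compounds shown do not pull these three apart. From the compounds shown here alone, how a 4-fluorophenyl ring, a 3-chlorophenyl ring or a ring bearing a methoxy group or an amine would fare in this assay remains open.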